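Swapping 4-hydroxyphenyl for 2,6-dichlorophenyl in compound 2

The source may report more compounds than this note shows. Statements on the series, on what has been measured and on what is new or still open speak of the compounds shown alone.

In a functional assay on HeLa cells (Homo sapiens) for cytotoxicity, read by MTT assay, with a stated time of 48 h (a lower number here means a stronger inhibitor, a higher number a weaker inhibitor), compound 2 (`COc1cc(/C=C/C(=O)C2=C(/C=C/c3ccc(O)c(OC)c3)NC(=O)NC2c2ccc(O)cc2)ccc1O`) gives 25000 nM, level with compound 3 (`COc1cc(/C=C/C(=O)C2=C(/C=C/c3ccc(O)c(OC)c3)NC(=O)NC2c2ccc(N(C)C)cc2)ccc1O`) at 25000 nM. Together they hold the lowest of the three numbers, while compound 1 (`COc1cc(/C=C/C(=O)C2=C(/C=C/c3ccc(O)c(OC)c3)NC(=O)NC2c2ccc(C)cc2)ccc1O`) gives 100000 nM. Compound 4 (`COc1cc(/C=C/C(=O)C2=C(/C=C/c3ccc(O)c(OC)c3)NC(=O)NC2c2c(Cl)cccc2Cl)ccc1O`) carries 2,6-dichlorophenyl in place of 4-hydroxyphenyl on a saturated ring carbon. Within the data shown here, no measured compound carries chlorine, so the evidence is indirect. Among the measured compounds shown here, the nearest guide is the one measured pair that differs by loss of the hydroxy group, a 4.0-fold lower number from compound 1 to compound 2 (0.60 log units; beyond the scatter), while the other exchange gives no change at the digits printed from compound 2 to compound 3 (within the scatter). A modest rise is therefore expected in this assay, an estimated 2.0-fold higher number from compound 2 to compound 4 (0.30 log units; within the scatter). Compound 4 is expected at 50000 nM, with an estimated range of 20000 nM to 120000 nM.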

Compound 4, half-maximal inhibitory concentration: 25000 nM
Beside the measured number, compound 4's estimate is 2.0-fold (0.30 log units) above it, within the range that was stated.
By their numbers in this assay, from the lowest: compounds 2, 3 and 4 (each within the scatter of the next); then compound 1.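

In this assay the step of no change at the digits printed from compound 2 to compound 4 (within the scatter) and the step of no change at the digits printed from compound 3 to compound 4 (within the scatter) show that this saturated ring carbon accepts 2,6-dichlorophenyl, with 0 hydrogen-bond donors and 0 hydrogen-bond acceptors, without departing from the level of the 4-hydroxyphenyl and 4-(dimethylamino)phenyl compounds. The step of a 4.0-fold lower number from compound 1 to compound 4 (0.60 log units; beyond the scatter) leaves compound 1, with its 4-methylphenyl group, alone apart from the other three. Nothing measured here explains this result. The compounds shown leave open whether a single chlorine on the phenyl ring would give the same number, and whether an aliphatic amine or a carboxylic acid on the phenyl ring would.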